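Carboxy to azidomethyl on the deoxy-sugar ring: expected binding

The compounds below may be only part of what the source reports. "The series", "measured", "known", "first", "only" and "open" are said of these compounds alone.

Measured compounds:
compound 1 `C[C@H]1OC(CO)C(O)C(O)C1O`: 53100000 nM
compound 2 `O=C(O)[C@H]1OC(CO)C(O)C(O)C1O`: 15200000 nM

In an assay on isolated protein (Oryctolagus cuniculus) for binding affinity to glycogen phosphorylase, brain form (Homo sapiens) (a higher number here means a weaker inhibitor, a lower number a stronger inhibitor), compound 2 stands at the lower of the two numbers, since the step of a 3.5-fold lower number from compound 1 to compound 2 (0.54 log units; beyond the scatter) lies beyond the scatter. Compound 3 `[N-]=[N+]=NC[C@H]1OC(CO)C(O)C(O)C1O` differs from compound 2 by azidomethyl in place of carboxy on a saturated ring carbon. For the measured compounds named here, only that one measured step bears on the change, and it was modest; with the carboxy gone, the gain seen from compound 1 to compound 2 may be partly lost. Compound 3 is therefore expected to show a 2.0-fold higher number from compound 2 to compound 3 (0.30 log units; within the scatter), a step that may stay within the scatter. The estimate for compound 3 is 30000000 nM, with a range from 10000000 nM to 100000000 nM.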

Compound 3, inhibition constant: 22400000 nM
Beside the measured number, compound 3's estimate is 1.3-fold (0.13 log units) above it, within the range that was stated.
By their numbers in this assay, from the lowest: compounds 2 and 3 (each within the scatter of the next); then compound 1.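

In this assay, exchanging carboxy for azidomethyl on this saturated ring carbon, next to the ring oxygen, gives a 1.5-fold higher number from compound 2 to compound 3 (0.17 log units; within the scatter), so the two groups cannot be told apart here. The gain over the methyl of compound 1 is therefore not tied to the carboxy: azidomethyl, with no hydrogen-bond donor, also gives a 2.4-fold lower number from compound 1 to compound 3 (0.37 log units; beyond the scatter). Nothing available explains this result. From the compounds shown here alone, how an aminomethyl group or a longer chain would compare at this position remains open, as does whether any group here can move the number well beyond that of compound 2.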